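The source may report more compounds than this note shows. Statements on the series, on what has been measured and on what is new or still open speak of the compounds shown alone.

Compound 1 `C=CCc1ccc(OCc2cn(-c3cccc([N+](=O)[O-])c3)nn2)c(O)c1`: 42.9%
Compound 2 `C=CCc1cc(O)c(O)c(CN2CCC(C)CC2)c1`: 91.5%

In a functional assay on MIA PaCa-2 cells (Homo sapiens) for inhibition, read by MTT assay, with a stated time of 72 h, tested at 30 uM (a higher number here means more inhibition of growth at the concentration tested, a lower number less inhibition of growth), compound 2 stands highest of the two measured compounds, with 91.5%. Compound 1 gives 42.9%. The gap between the two compounds lies beyond the scatter. Compound 3 `C=CCc1cc(O)c(O)c(CN2CCC(CCO)CC2)c1` changes compound 2 in one place: hydroxymethyl in place of hydrogen on a saturated chain carbon bound to a saturated ring carbon. Within the data shown here, no measured pair shows the effect of this change, so the forecast is uncertain. Expected in this assay is a number 11.5 percentage points lower from compound 2 to compound 3 (beyond the scatter), a modest fall that may stay within the scatter. For compound 3 the estimated value is 80%, with an expected range of 55% to 97%.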

Compound 3, percent growth inhibition at one concentration: 54.4%
Estimate against measurement, compound 3: 25.6 percentage points above; the whole stated range lies above it.
By their numbers in this assay, from the lowest: compound 1; then compound 3; then compound 2.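

With hydroxymethyl on a saturated chain carbon bound to a saturated ring carbon, this assay shows a number 37.1 percentage points lower from compound 2 to compound 3 (beyond the scatter), so growth inhibition here depends on what this place carries. In other words, going from methyl to 2-hydroxyethyl is not a neutral change. No evidence at hand explains the fall. Open, on these data alone, is whether the fall goes with the longer chain or with its oxygen, and an ethyl group at this place would separate the two. As far as these compounds go, how an amine or a carboxylic acid at the end of that chain would behave also stays open.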